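The source may report more compounds than this note shows. Statements on the series, on what has been measured and on what is new or still open speak of the compounds shown alone.

Values measured in an ADME assay on microsomes from liver (Homo sapiens) for metabolic stability, read by LC-MS, using NADPH, with a stated time of 30 min, tested at 0.1 uM; a higher number here means that more of the compound is left, a lower number that less of the compound is left:
- compound 1 `CS(=O)(=O)Nc1ccc2nccc(-c3ccncc3)c2n1`: 96%
- compound 2 `O=S(=O)(c1cccc(-c2ccc3nccc(-c4ccncc4)c3n2)c1)N1CCC(O)CC1`: 5%
- compound 3 `CS(=O)(=O)Nc1cccc(-c2ccc3nccc(-c4ccncc4)c3n2)c1`: 59%

Compound 3 holds the second highest number of the three: it stands at 59%, while compound 1 gives 96% and compound 2 gives 5%. The next compound to consider is compound 4 `Nc1cccc(-c2ccc3nccc(-c4ccncc4)c3n2)c1`. The change is hydrogen in place of methylsulfonyl on a nitrogen on an aromatic ring, so that methanesulfonamido becomes amino.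

Going by the values given here, only one measured step bears on this, and only indirectly. Going to the methanesulfonamido group, a number 54 percentage points higher from compound 2 to compound 3 (beyond the scatter), a large step beyond the scatter, but it exchanged a whole group on an aromatic carbon. Among the compounds with values here, no measured step removes methylsulfonyl alone, so the direction stays open. The expectation in this assay is therefore no step beyond the scatter, with a number 4 percentage points lower from compound 3 to compound 4 (within the scatter) as the expected step. The size of the step to compound 3, a number 54 percentage points higher from compound 2 to compound 3 (beyond the scatter), argues for a wide range. For compound 4 the estimated value is 55%, with an expected range from 25% to 80%.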

Compound 4, percent of the compound remaining: 78%
Compound 4: middle estimate off by 23 percentage points, on the low side, and the stated range covers the measured number.
By their numbers in this assay, from the lowest: compound 2; then compound 3; then compound 4; then compound 1.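

In (this assay) the step that removes methylsulfonyl alone from the nitrogen on the aromatic ring is now measured, and it shows (a number 19 percentage points higher from compound 3 to compound 4 (beyond the scatter)), so amino stands above methanesulfonamido at this place. The amino group also lies far above (4-hydroxypiperidin-1-yl)sulfonyl on the aromatic carbon (a number 73 percentage points higher from compound 2 to compound 4 (beyond the scatter)), yet 3-aminophenyl does not reach methanesulfonamido placed on the aromatic carbon of the core of compound 1 (a number 18 percentage points lower from compound 1 to compound 4 (beyond the scatter)). Nothing available explains why the numbers move in this way.

On these data alone, whether an acetyl or a methyl group on that nitrogen would fall nearer to amino or to methanesulfonamido stays open, as does what a carboxylic acid on the same aromatic carbon would give. The compounds shown also leave open whether the step from methylsulfonyl to hydrogen would hold on another core.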